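Acetyl in place of furan-2-yl on the shared core

A few compounds are considered here, and "the series" means these few. Any claim that something is new, unique, unknown or untested is made for them only; others in the source may bear on it.

In an assay on isolated protein for inhibition of DNA topoisomerase 1 (Homo sapiens) (on this read-out higher numbers stand for weaker inhibition and lower numbers for stronger inhibition), the measured compounds are:
Compound 1, `O=C1C=CC(=O)c2cc(OCc3ccccc3)ccc21`, gives 53700 nM.
Compound 2, `O=C1C=CC(=O)c2c(Oc3cccs3)cccc21`, reaches only a limit of the assay, > 100000 nM.
Compound 3, `O=C1C=CC(=O)c2cc(Oc3ccco3)ccc21`, likewise reaches only a limit of the assay, > 100000 nM.

Compound 3 thus stands at the edge of what this assay can report, where (the limit of > 100000 nM in this assay, at which 2 of the 3 values shown sit), and only compound 1 has a measured number. Compound 4, `CC(=O)Oc1ccc2c(c1)C(=O)C=CC2=O`, differs from compound 3 by acetyl in place of furan-2-yl on an oxygen on an aromatic ring. Going by the values given here, no step between measured compounds is available to size this change, so the expectation is cautious: the step of an at least 1.2-fold lower number from compound 3 to compound 4 (0.09 log units; that floor lies within the scatter) is expected to be small, if any, towards slightly stronger inhibition, with inhibition remaining weak. Compound 4 is expected to give about 80000 nM, between 30000 nM and 200000 nM, with a fair chance that only a limit is reported again.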

Compound 4, half-maximal inhibitory concentration: > 100000 nM
Compound 4: only a limit was reported (the forecaster's own chance of this, stated with the estimate: 50%); at least 1.2-fold (0.09 log units) between middle value and limit.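

Compound 3 and compound 4 both reach only a limit in this assay, so the step between them cannot be read: the limit of > 100000 nM in this assay, at which 3 of the 4 values shown sit.

As far as these compounds go, whether acetyl in place of furan-2-yl changes inhibition at all remains open.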